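A few compounds are considered here, and "the series" means these few. Any claim that something is new, unique, unknown or untested is made for them only; others in the source may bear on it.

Of the compounds shown here, three that share one core have been measured in an assay on HEK293 cells for agonist activity at Toll-like receptor 8 (Homo sapiens), read by a luciferase reporter, with a stated time of 6 h; on this read-out higher numbers stand for an effect only at larger amounts of compound and lower numbers for an effect already at smaller amounts. Compound 1 `CCCCNc1nc(N)nc2c1CN(S(C)(=O)=O)CC2` gives 9.9 uM. Compound 2 `CCCCNc1nc(N)nc2c1CN(Cc1ccncc1)CC2` gives 0.29 uM, and compound 3 `CCCCNc1nc(N)nc2c1CN(C(=O)CC)CC2` gives 0.4 uM. Compound 3 thus stands second highest of the three numbers; its nearest neighbour is compound 2, with which it lies within the scatter, while compound 1 lies furthest away. The measured steps read a 25-fold lower number from compound 1 to compound 3 (1.39 log units; beyond the scatter) and a 1.4-fold higher number from compound 2 to compound 3 (0.14 log units; within the scatter), so exchanging the group on the ring nitrogen has moved the read-out strongly in one case and hardly at all in the other.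

Compound 4 `CCCCNc1nc(N)nc2c1CN(C(=O)c1csc(N)n1)CC2` differs from compound 3 in 2-amino-1,3-thiazol-4-yl in place of ethyl on a carbonyl carbon. Within the data shown here, no measured step touches the carbonyl carbon itself: both known steps replace the whole group on the ring nitrogen, and the values of compound 2 and compound 3 sit within the scatter of each other. On that footing a step of no change at the digits printed from compound 3 to compound 4 (within the scatter) is expected, nothing beyond the scatter. Compound 4 is therefore estimated at 0.4 uM, within a range from 0.1 uM to 1.6 uM.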

Compound 4, minimum effective concentration: 6.9 uM
Compound 4: the middle estimate sits 17-fold (1.24 log units) below what was measured, outside the stated range (above it).
By their numbers in this assay, from the lowest: compounds 2 and 3 (each within the scatter of the next); then compounds 4 and 1 (each within the scatter of the next).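

In this assay the group on the carbonyl carbon proves to matter: with 2-amino-1,3-thiazol-4-yl in place of ethyl there is a 17-fold higher number from compound 3 to compound 4 (1.24 log units; beyond the scatter) and so the carbonyl on the ring nitrogen does not by itself keep the read-out near that of compound 3. Set against the (pyridin-4-yl)methyl group, the (2-amino-1,3-thiazol-4-yl)carbonyl group gives a 24-fold higher number from compound 2 to compound 4 (1.38 log units; beyond the scatter) while against methylsulfonyl it gives only a 1.4-fold lower number from compound 1 to compound 4 (0.16 log units; within the scatter) and methylsulfonyl therefore no longer stands alone at the high end of the read-out. Nothing available explains this shift.

The compounds shown leave open whether the higher number goes with the thiazole ring or with its amino group. They also do not tell how a phenyl group or a longer chain such as butyl on the carbonyl carbon would read.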